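A Single Fluoro Added to Compound 2

The source may report more compounds than this note shows. Statements on the series, on what has been measured and on what is new or still open speak of the compounds shown alone.

Compound 2 `Cc1cc(=O)n(-c2ccc(Br)cc2F)nc1C(=O)Nc1ccc(Oc2ncnc3sccc23)cc1`: 12800 nM
Compound 1 `CNC(=O)c1cc(Oc2ccc(NC(=O)c3nn(-c4ccc(Br)cc4F)c(=O)cc3C)cc2F)ccn1`: 7930 nM

For the measured compounds named here, in a functional assay on A549 cells (Homo sapiens) for cytotoxicity, read by MTT assay, with a stated time of 72 h (a lower number here means a stronger inhibitor, a higher number a weaker inhibitor), compound 2 gives 12800 nM, the larger of the two numbers measured so far. Compound 1, with a different ring system on the ether, gives 7930 nM, and the gap between the two lies within the scatter, so they cannot be told apart on these numbers alone. Both are weak inhibitors here.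

Compound 3 `Cc1cc(=O)n(-c2ccc(Br)cc2F)nc1C(=O)Nc1ccc(Oc2ncnc3sccc23)c(F)c1` differs from compound 2 in one place only: fluoro in place of hydrogen on an aromatic carbon. Going by the values given here, no measured pair shows what this kind of change does to this assay, so nothing in the data points in either direction. The step expected from compound 2 to compound 3 is therefore small, a 1.4-fold lower number from compound 2 to compound 3 (0.15 log units; within the scatter), nothing beyond the scatter. Compound 3 is estimated at 9000 nM, with a range from 3500 nM to 25000 nM.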

Compound 3, half-maximal inhibitory concentration: 11500 nM
The estimate for compound 3 lay 1.3-fold (0.11 log units) below the measured number; the measured number falls inside the stated range.
By their numbers in this assay, from the lowest: compounds 1, 3 and 2 (each within the scatter of the next).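

In this assay, putting fluoro in place of hydrogen on this aromatic carbon, ortho to a large group and meta to a large group, gives a 1.1-fold lower number from compound 2 to compound 3 (0.05 log units; within the scatter) and so leaves the number inside the scatter, the first measured sign of what this change does here. Compound 3 also stays close to compound 1, with a 1.5-fold higher number from compound 1 to compound 3 (0.16 log units; within the scatter) and thus no measurable difference between the two groups on the oxygen, now that both compounds carry this fluoro. Nothing available explains why these numbers stay so close.

Fluoro is a single small atom, so it remains open whether a chloro, a methoxy or an amine at this same carbon would shift the number beyond the scatter. All three compounds are weak here, and these numbers do not show which changes could make them stronger.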